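A few compounds are considered here, and "the series" means these few. Any claim that something is new, unique, unknown or untested is made for them only; others in the source may bear on it.

Measured so far:
- compound 1, `CN(C)CCCNc1nc(-c2ccc(NC(=O)Nc3ccc(F)cc3)cc2)nc2c(Cl)c(Cl)sc12`: 430 nM
- compound 2, `CN(C)CCCNc1nc(-c2ccc(NC(=O)Nc3ccccc3Cl)cc2)nc2ccsc12`: 390 nM
- compound 3, `CN(C)CCNc1nc(-c2ccc(NC(=O)Nc3ccccc3)cc2)nc2ccsc12`: 620 nM

In a functional assay on HT-29 cells (Homo sapiens) for cytotoxicity, read by MTT assay, with a stated time of 72 h (a higher number here means a weaker inhibitor, a lower number a stronger inhibitor), compound 3 gives the highest number of the three, but its gaps to compound 1 and to compound 2 both lie within the usual scatter, so the three values are read as one level and no order among them is claimed. For the measured compounds named here, compounds 1 and 2 differ from compound 3 in more than one place at once, so no single step between measured compounds is available.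

Compound 4, `CN(C)CCNc1nc(-c2ccc(NC(=O)Nc3ccc(Cl)cc3Cl)cc2)nc2ccsc12`, differs from compound 3 in one place: 2,4-dichlorophenyl in place of phenyl on an amide-type nitrogen. Compounds 1 and 2, which carry a halogen-substituted phenyl on that same urea nitrogen, sit within the scatter of compound 3, which gives no sign that a halogenated phenyl there moves the number. The expectation for compound 4 is accordingly a value close to that of compound 3, in either direction and not beyond the scatter. The expected step, a 1.2-fold lower number from compound 3 to compound 4 (0.09 log units; within the scatter), is estimated to stay within the scatter. Compound 4 is estimated at 500 nM, with a range of 220 nM to 1100 nM.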

Compound 4, half-maximal inhibitory concentration: 1320 nM
Compound 4: the middle estimate sits 2.6-fold (0.42 log units) below what was measured; measured number above the stated range.
By their numbers in this assay, from the lowest: compounds 2, 1 and 3 (each within the scatter of the next); then compound 4.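

In this assay, for the compounds shown here, the change from phenyl to 2,4-dichlorophenyl on the amide-type nitrogen gives a 2.1-fold higher number from compound 3 to compound 4 (0.33 log units; beyond the scatter), the first single-place step, so this position is not indifferent to its substituent. Compounds 1 and 2 also carry a halogen-substituted phenyl on this nitrogen, but each differs from compound 3 in more than one place, so neither isolates the change or counts as evidence against the step. No measurement at hand accounts for the step.

On these data alone, it remains open whether both chlorines are needed for the step or a phenyl with a single chlorine would show it too, and whether a methoxy group on that phenyl would behave differently. Also open, as far as these compounds go, is whether the step carries over to the longer side chain of compounds 1 and 2.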